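A few compounds are considered here, and "the series" means these few. Any claim that something is new, unique, unknown or untested is made for them only; others in the source may bear on it.

Values in a functional assay on A9L-m1 cells with A9 (Mus musculus) as the target (a lower number here means that less compound is needed, a higher number that more compound is needed for the effect), for the measured compounds:
Compound 1 `CCCCOc1nccnc1C1CN2CCC1CC2` gives 24100000 nM
Compound 2 `CCCCCOc1nccnc1C1CN2CCC1CC2` gives 9130000 nM

Compound 2 holds the lower of these two numbers, and its 9130000 nM is the lowest so far. The unmeasured compound 3 `CCCCCCSc1nccnc1C1CN2CCC1CC2` carries hexylsulfanyl in place of pentyloxy on an aromatic carbon next to the ring nitrogen hexylsulfanyl in place of pentyloxy on an aromatic carbon and is otherwise unchanged. Among the compounds with values here, one measured step bears on this: a 2.6-fold lower number from compound 1 to compound 2 (0.42 log units; beyond the scatter) came with methyl in place of hydrogen on a saturated chain carbon and is modest but beyond the scatter. Within the data shown here, the chain in compound 3 also grows, but no measured step covers sulfur in place of oxygen, so the range stays wide. The estimated step in this assay is a 2.3-fold lower number from compound 2 to compound 3 (0.36 log units; beyond the scatter) and so is expected to be similarly modest, toward a lower number. Compound 3 is expected at 4000000 nM with 1000000 nM to 14000000 nM as the estimated range.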

Compound 3, half-maximal effective concentration: 270000 nM
For compound 3 the middle estimate is 15-fold (1.17 log units) above the measured one; measured number outside the range, below it.
By their numbers in this assay, from the lowest: compound 3; then compound 2; then compound 1.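

In this assay the exchange of pentyloxy for hexylsulfanyl on an aromatic carbon next to the ring nitrogen gave a 34-fold lower number from compound 2 to compound 3 (1.53 log units; beyond the scatter) and thus a much larger change than the earlier chain step, a 2.6-fold lower number from compound 1 to compound 2 (0.42 log units; beyond the scatter). Measured against the butoxy group, the same position shows an 89-fold lower number from compound 1 to compound 3 (1.95 log units; beyond the scatter), so the group held here can move the number over a far wider span than the two oxygen-linked chains alone had shown. Nothing available explains the size of this step.

The step changes the linking atom and the chain together, so the compounds shown cannot separate the share of sulfur from that of the added carbon; hexyloxy and pentylsulfanyl would divide the two. Going by these compounds, whether a longer sulfur-linked chain or an amine at this position would lower the number further stays open.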